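Chalcone lactones: antiproliferative read-out, next step

The compounds below may be only part of what the source reports. "The series", "measured", "known", "first", "only" and "open" are said of these compounds alone.

Measured compounds:
compound 1 `CC(C)c1ccc(/C=C/C(=O)c2ccc(OCC(=O)N[C@H]3CCOC3=O)cc2)cc1` — 4660 nM
compound 2 `O=C(CNc1ccccc1F)N[C@H]1CCOC1=O` — > 64000 nM
compound 3 `CC(=O)c1ccc(OCCSC(=S)N[C@H]2CCOC2=O)cc1` — 46900 nM

In a functional assay on PC-3 cells (Homo sapiens) for antiproliferative activity, read by MTT assay, with a stated time of 72 h (on this read-out lower numbers stand for stronger inhibition and higher numbers for weaker inhibition), compound 1 gives 4660 nM, the lower of the two numbers in hand. The nearest number is that of compound 3, which in this assay gives 46900 nM; the gap to compound 1 lies beyond the usual scatter. For compound 2 the read-out in this assay is a limit of the assay and not a number, > 64000 nM. That boundary is the limit of > 64000 nM in this assay, at which 1 of the 3 values shown sits.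

Compound 4 `O=C(COc1ccc(C(=O)/C=C/c2ccc(Cl)cc2Cl)cc1)N[C@H]1CCOC1=O` has not yet been measured in this assay. It differs from compound 1 in one place: 2,4-dichlorophenyl in place of 4-isopropylphenyl on a double-bonded chain carbon bound to a double-bonded chain carbon. Among the measured compounds shown here, no pair of measured compounds shares this change, so no measured step sets its size. The expectation is a step of no more than the scatter, a 1.2-fold lower number from compound 1 to compound 4 (0.07 log units; within the scatter). Compound 4 is thus estimated in this assay at 4000 nM, with a range from 1500 nM to 12000 nM.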

Compound 4, half-maximal inhibitory concentration: 8040 nM
Estimate against measurement, compound 4: 2.0-fold (0.30 log units) below; measured number inside the range.
By their numbers in this assay, from the lowest: compounds 1 and 4 (each within the scatter of the next); then compound 3. At a limit, above all of these: compound 2.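

In this assay, 2,4-dichlorophenyl in place of 4-isopropylphenyl on a double-bonded chain carbon bound to a double-bonded chain carbon gives a 1.7-fold higher number from compound 1 to compound 4 (0.24 log units; within the scatter). Among the compounds shown here, this is the first single-place step, and it shows that this position can carry either of these two aryl groups with no difference readable beyond the scatter, so the read-out does not separate them. No measured property in hand bears on this step.

Open, as far as these compounds go, is whether a carboxylic acid or an amine on the ring at this place would stay within the scatter of compound 1 or move beyond it. Also open is what the double-bonded chain itself contributes, as no pair shown tests it in one place.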